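Amide series: all cytotoxicity readings sit at the assay limit

The source may report more compounds than this note shows. Statements on the series, on what has been measured and on what is new or still open speak of the compounds shown alone.

Compound 1, `C=CC1=C(C(=O)NC(C)(C)C)C(c2ccc(OC)cc2)OC1`: in a functional assay on A549 cells (Homo sapiens) for cytotoxicity, read by MTT assay, with a stated time of 24 h (on this read-out lower numbers stand for stronger inhibition and higher numbers for weaker inhibition), compound 1 gives > 100000 nM, which is a limit of the assay.
Compound 2, `C=CC1=C(C(=O)NCc2ccc(Cl)cc2)C(c2ccc(OC)cc2)OC1`: in this assay compound 2 gives > 100000 nM, again a limit.
Compound 3, `C=CC1=C(C(=O)NCc2ccc(C)cc2)C(c2ccc(OC)c(OC)c2)OC1`: in this assay compound 3 gives > 100000 nM, also a limit.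

Compound 3 therefore stands only at a limit, with no number that would place it against the other two; the whole set shares (the limit of > 100000 nM in this assay, at which 3 of the 3 values shown sit). Among the compounds with values here, the one step between measured compounds, a step that the two limits leave unreadable from compound 1 to compound 2, is left unreadable by the two limits and gives no size in either direction.

Compound 4, `C=CC1=C(C(=O)NCc2ccc(C)cc2)C(c2ccc(OC)cc2)OC1`, differs from compound 3 by hydrogen in place of methoxy on an aromatic carbon. Within the data shown here, no measured step touches this change, and the step from compound 1 to compound 2 cannot be used to read its size. With three limits and nothing else, the expectation for compound 4 in this assay is that it stays at the limit as well; a step beyond the scatter in either direction cannot be read from the series.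

Compound 4 is expected at 100000 nM, with a range from 40000 nM to 300000 nM. The step from compound 3 to compound 4 is thus estimated as a number no higher from compound 3 to compound 4 (the limit leaves the size open), most likely returned as a limit.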

Compound 4, half-maximal inhibitory concentration: > 100000 nM
Compound 4: a limit, no number; the forecaster's own chance of this, stated with the estimate: 85%; the middle value lies on the limit itself.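

The steps from compound 1, compound 2 and compound 3 to compound 4 cannot be read in this assay, and no new step results, because all four readings are limits: the limit of > 100000 nM in this assay, at which 4 of the 4 values shown sit.

The compounds shown leave open whether any change among them, on the amide nitrogen or the aromatic carbons, shifts cytotoxicity by a readable amount.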